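The compounds below may be only part of what the source reports. "The series", "measured", "known", "first", "only" and "open" are said of these compounds alone.

Compound 2, `CC#C[C@@H](CC(=O)O)c1ccc(OC[C@H]2COc3ccc(Br)cc3O2)cc1`, gives the lower of the two numbers recorded in a functional assay on HEK293 cells for agonist activity at Free fatty acid receptor 1 (Homo sapiens), read by fluorescence and calcium flux, with a stated time of 10 min; a lower number here means that less compound is needed, a higher number that more compound is needed for the effect: compound 2 reaches 210 nM. Compound 1, `Cn1ccnc1C(CC(=O)O)c1ccc(OCC2COc3ccc(Cl)cc3O2)cc1`, sits far from it; in this assay compound 1 gives 5880 nM, and the two compounds differ in more than one place, so the gap between them cannot be traced to a single change. Compound 3, `CC#C[C@@H](CC(=O)O)c1ccc(OC[C@H]2COc3ccc(C(C)=O)cc3O2)cc1`, is the unmeasured partner of compound 2 and differs from it only by acetyl in place of bromo on an aromatic carbon. Within the data shown here, no measured pair in this set isolates such an exchange, so the expectation rests on the change itself. A moderate step upward in concentration is expected from compound 2 to compound 3, a 2.4-fold higher number from compound 2 to compound 3 (0.38 log units; beyond the scatter), on the border of the usual scatter. Compound 3 is therefore estimated to reach 500 nM in this assay, within a range of 150 nM to 1800 nM.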

Compound 3, half-maximal effective concentration: > 30000 nM
Compound 3 ended at the assay's limit; the forecaster's own chance of this, stated with the estimate: 3%; middle value at least 60-fold (1.77 log units) away from the limit.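

Placed on an aromatic carbon of the six-membered ring, meta to a fused ring and para to a fused ring, acetyl in place of bromo gives an at least 140-fold higher number from compound 2 to compound 3 (2.15 log units; beyond the scatter) in this assay. Among these compounds, this is the first single exchange available in the set, and it shows that this position does not tolerate every replacement of bromo, with activity lost far beyond the usual scatter. For compound 3, > 30000 nM is a limit of the assay and not a number, so the full size of the step stays unknown: the limit of > 30000 nM in this assay, at which 1 of the 3 values shown sits.

The pair cannot say whether the loss belongs to the carbonyl or to the two extra heavy atoms. Going by these compounds, how a nitrile, a methoxy group or a methyl group would behave at this carbon remains open.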